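A Ring Nitrogen Enters the Core of Compound 3

The source may hold more compounds than are shown below. What is called first, only, known or untested is meant among the compounds shown, and "the series" means these compounds.

Three urea compounds have been tested in a functional assay on Bel-7402 cells (Homo sapiens) for cytotoxicity, read by MTT assay, with a stated time of 72 h; on this read-out lower numbers stand for stronger inhibition and higher numbers for weaker inhibition. Compound 1 `O=C(Nc1ccc(-n2ncc3c(F)cccc32)cc1)Nc1ccc(Cl)c(C(F)(F)F)c1` gives 16000 nM, compound 2 `Cc1cccc2c1cnn2-c1ccc(NC(=O)Nc2ccc(Cl)c(C(F)(F)F)c2)cc1` gives 6700 nM, and compound 3 `O=C(Nc1ccc(-n2ncc3ccccc32)cc1)Nc1ccc(Cl)c(C(F)(F)F)c1` gives 10600 nM. Compound 3 stands second highest of the three numbers; its nearest neighbour is compound 1 and its furthest is compound 2, and both gaps fall within the scatter: a 1.5-fold lower number from compound 1 to compound 3 (0.18 log units; within the scatter) and a 1.6-fold higher number from compound 2 to compound 3 (0.20 log units; within the scatter). Going by the values given here, the one step that goes beyond the scatter is a 2.4-fold lower number from compound 1 to compound 2 (0.38 log units; beyond the scatter).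

Compound 4 `O=C(Nc1ccc(-n2ncc3cnccc32)cc1)Nc1ccc(Cl)c(C(F)(F)F)c1` has not yet been measured. It differs from compound 3 in one place: a group of 9 heavy atoms (6 carbon, 3 nitrogen; one five-membered aromatic ring with 2 hetero atoms, one six-membered aromatic ring with 1 hetero atom) in place of a group of 9 heavy atoms (7 carbon, 2 nitrogen; one five-membered aromatic ring with 2 hetero atoms, one six-membered aromatic ring of carbon only), on an aromatic carbon. Among the compounds with values here, none of the measured steps changes a ring atom in this way; all three swap a substituent on the six-membered aromatic ring of carbon only within the shared core, and those swaps moved the number little. Within the data shown here, with that as the only guide, compound 4 is expected to sit close to compound 3, the expected step being a 1.1-fold lower number from compound 3 to compound 4 (0.03 log units; within the scatter), with no clear direction beyond the scatter. The estimate for compound 4 in this assay is 10000 nM, with an expected range from 4000 nM to 25000 nM.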

Compound 4, half-maximal inhibitory concentration: 2700 nM
Estimate against measurement, compound 4: 3.7-fold (0.57 log units) above; the whole stated range lies above it.
By their numbers in this assay, from the lowest: compound 4; then compounds 2, 3 and 1 (each within the scatter of the next, the first and the last beyond it).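

In this assay, the change from compound 3 to compound 4 alters an atom of the ring itself, so that a six-membered aromatic ring with 1 hetero atom replaces the one of carbon only, and this gives a clear drop in the number (a 3.9-fold lower number from compound 3 to compound 4 (0.59 log units; beyond the scatter)). The fluoro, methyl and hydrogen swaps on that ring never reached so low a number, and compound 4 also stands apart from both substituted compounds (a 2.5-fold lower number from compound 2 to compound 4 (0.39 log units; beyond the scatter); a 5.9-fold lower number from compound 1 to compound 4 (0.77 log units; beyond the scatter)), which makes it the most potent of the four on this read-out. What lies behind the drop stays unknown, as no measurement shown here bears on it.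

Only one placement of the ring nitrogen appears among these compounds, so it remains open whether the gain belongs to that exact spot or would appear with the nitrogen elsewhere in the same ring. From the compounds shown here alone, it is also open whether fluoro or methyl would add to the gain on the nitrogen-containing ring, and how a different group there, such as an amine or a methoxy group, would shift the number.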